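The source may hold more compounds than are shown below. What is called first, only, known or untested is meant among the compounds shown, and "the series" means these compounds.

Compound 1 `CC(CCNC(=O)c1c(Cl)cncc1Cl)N1CCC(C(Oc2cccc(C#N)n2)c2ccc(C(F)(F)F)cc2)CC1`: 15700 nM
Compound 2 `CC(CCNC(=O)c1c(Cl)cncc1Cl)N1CCC(C(=O)c2ccc(Br)cc2)CC1`: 189000 nM

In an ADME assay on PBMC cells (Homo sapiens) for cytotoxicity (a higher number here means that more compound is tolerated, a lower number that less compound is tolerated), compound 1 gives 15700 nM, the lower of the two numbers measured; compound 2 gives 189000 nM, a higher number that lies beyond the scatter. Compound 3 `COC(=O)c1cccc(OC(c2ccc(C(F)(F)F)cc2)C2CCN(C(C)CCNC(=O)c3c(Cl)cncc3Cl)CC2)c1` has not been measured. It differs from compound 1 by 3-(methoxycarbonyl)phenyl in place of 6-cyanopyridin-2-yl on an oxygen on a saturated carbon. Among the compounds with values here, no comparable step between measured compounds exists, so the step from compound 1 to compound 3 in this assay is expected to be small, in either direction, and likely within the scatter, as a 1.1-fold higher number from compound 1 to compound 3 (0.06 log units; within the scatter). Compound 3 is therefore estimated at 18000 nM, within a range of 6000 nM to 50000 nM.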

Compound 3, half-maximal cytotoxic concentration: 15200 nM
The estimate for compound 3 lay 1.2-fold (0.07 log units) above the measured number, and the stated range covers the measured number.
By their numbers in this assay, from the lowest: compounds 3 and 1 (each within the scatter of the next); then compound 2.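

In this assay, 3-(methoxycarbonyl)phenyl in place of 6-cyanopyridin-2-yl on an oxygen on a saturated carbon gives a 1.0-fold lower number from compound 1 to compound 3 (0.01 log units; within the scatter). Within the data shown here, this is the first comparison at this position in which only one place differs, and it shows that this exchange of a ring with one hetero atom for a ring of carbon only leaves the read-out within the scatter. Nothing measured here bears on why the two compounds read alike. The compounds shown leave open whether a carboxylic acid or an amine in place of the methoxycarbonyl group would also leave this assay unchanged.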